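Nitrooxy in Place of Methyl on the Sulfonyl Ring

The source may hold more compounds than are shown below. What is called first, only, known or untested is meant among the compounds shown, and "the series" means these compounds.

Compound 1 `CC(=O)Nc1ccc(S(=O)(=O)N2C/C(=C\c3ccccc3F)C(=O)/C(=C/c3ccccc3F)C2)cc1` gives 11500 nM in an ADME assay on L02 cells (Homo sapiens) for cytotoxicity, read by MTT assay, with a stated time of 24 h; a higher number here means a weaker inhibitor, a lower number a stronger inhibitor.
Compound 2 `O=C1/C(=C/c2ccc(F)cc2)CN(S(=O)(=O)c2ccccc2)C/C1=C\c1ccc(F)cc1` gives 18800 nM in this assay.
Compound 3 `Cc1ccc(S(=O)(=O)N2C/C(=C\c3ccc(F)cc3)C(=O)/C(=C/c3ccc(F)cc3)C2)cc1` gives 14000 nM in this assay.

The three measured compounds share one core and differ only in the group on the sulfonyl-bearing aromatic ring. Compound 3 has the second highest of the three numbers, but its distance to compound 1 and its distance to compound 2 are both within the scatter, so no order among them can be read from these values.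

Compound 4 `O=C1/C(=C/c2ccc(F)cc2)CN(S(=O)(=O)c2ccc(O[N+](=O)[O-])cc2)C/C1=C\c1ccc(F)cc1` differs from compound 3 in one place: nitrooxy in place of methyl on an aromatic carbon. Among the compounds with values here, the only measured step that touches this position is a 1.3-fold lower number from compound 2 to compound 3 (0.13 log units; within the scatter), in which a methyl entered the same ring; that step stayed within the scatter. Within the data shown here, no measured step introduces a nitrooxy group, so the data give no direction for this exchange. On this basis a step of no size beyond the scatter is expected in this assay, that is, no change at the digits printed from compound 3 to compound 4 (within the scatter) is the expected change.

Compound 4 is therefore estimated to give 14000 nM in this assay, with a range from 7000 nM to 28000 nM.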

Compound 4, half-maximal inhibitory concentration: 16200 nM
Beside the measured number, compound 4's estimate is 1.2-fold (0.06 log units) below it, within the range that was stated.
By their numbers in this assay, from the lowest: compounds 1, 3, 4 and 2 (each within the scatter of the next).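

In this assay, within the data shown here, the step of a 1.2-fold higher number from compound 3 to compound 4 (0.06 log units; within the scatter) is the first measured exchange that places nitrooxy on this aromatic carbon, para to a large group, and it stays within the scatter. The step of a 1.2-fold lower number from compound 2 to compound 4 (0.06 log units; within the scatter) is also within the scatter, so compound 4 cannot be told apart from either its methyl or its unsubstituted counterpart in this assay. The position thus carries nitrooxy, with 4 heavy atoms and 3 hydrogen-bond acceptors, in place of methyl, with 1 heavy atom and none, without a step beyond the scatter, a result that the methyl step alone could not show. No measurement at hand offers an explanation for this result.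

Going by these compounds, all the groups compared at this position sit on the same bis(4-fluorobenzylidene) framework, so it remains open whether nitrooxy would give the same outcome if the groups elsewhere on the shared core were different. On these data alone, it also remains open whether a group of another kind at this carbon, such as an amine, a carboxylic acid or a longer chain, would give a step beyond the scatter.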